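Swapping oxan-4-yl for cyclopropyl on compound 2

This account rests on a few compounds, and the source may have more. Where it says the series, first, only, none or still open, it means among the compounds named here.

In a physicochemical assay for lipophilicity, read by HPLC, at pH 7.4 (on this read-out higher numbers stand for higher lipophilicity and lower numbers for lower lipophilicity), compound 2 (`CCC/N=C1\S/C(=C\c2ccc(O)c(Cl)c2)C(=O)N1C1CCOCC1`) gives 3.7, within the scatter of compound 1 (`CCC/N=C1\S/C(=C\c2ccc(O)c(C(F)(F)F)c2)C(=O)N1c1ccccc1C`) at 3.8 and compound 3 (`CCC/N=C1\S/C(=C\c2ccc(O)c(C)c2)C(=O)N1c1ccccc1C`) at 3.8. Compound 4 (`CCC/N=C1\S/C(=C\c2ccc(O)c(Cl)c2)C(=O)N1C1CC1`) has not yet been measured. It differs from compound 2 as follows: cyclopropyl in place of oxan-4-yl on an amide-type nitrogen in a ring. Among the compounds with values here, the only measured step, no change at the digits printed from compound 1 to compound 3 (within the scatter), is methyl in place of trifluoromethyl on an aromatic carbon, so it lies at another place. Within the data shown here, no measured step covers this nitrogen, and the direction is therefore a judgement. A small upward move is expected, namely a number 0.30 log units higher from compound 2 to compound 4 (within the scatter). For compound 4 the estimated value in this assay is 4, with an expected range from 3.6 to 4.4.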

Compound 4, distribution coefficient: 3.4
Estimate against measurement, compound 4: 0.60 log units above; the whole stated range lies above it.
By their numbers in this assay, from the lowest: compounds 4, 2, 1 and 3 (each within the scatter of the next, the first and the last beyond it).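

Within the data shown here, the step at this position, the amide-type nitrogen in a ring, is the first one measured there: in this assay, cyclopropyl in place of oxan-4-yl gives a number 0.30 log units lower from compound 2 to compound 4 (within the scatter). Exchanging a six-membered ring holding one oxygen for a three-membered ring of carbon only, with the hydrogen-bond acceptor gone, therefore stays within the scatter here. No measurement at hand bears on the reason for this result.

The compounds shown leave open whether a longer chain or an amine on this nitrogen would also stay within the scatter of compound 2.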